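The compounds below may be only part of what the source reports. "The series", "measured", "known", "first", "only" and "open" are said of these compounds alone.

Measured compounds:
Compound 1, `O=C(NO)c1cccc(-c2cn([C@H]3C[C@H](CO)N(CCCc4ccccc4)C3)nn2)c1`: < 10% in an assay on Sf9 cells for inhibition of histone deacetylase 11 (Homo sapiens), read by fluorescence, tested at 0.5 uM (a higher number here means more inhibition at the concentration tested (going by the name of the read-out), a lower number less inhibition), which is a limit of the assay and not a number.
Compound 2, `O=C(NO)c1ccc(-c2cn([C@H]3C[C@H](CO)N(CCCc4ccccc4)C3)nn2)cc1`: 18% in this assay.

Compound 1 stands at the lower edge of what the two values show, since its result is the limit (the limit of < 10% in this assay, at which 1 of the 2 values shown sits). Within the data shown here, the single measured step, a number at least 8 percentage points higher from compound 1 to compound 2 (that floor lies within the scatter), puts 4-(hydroxycarbamoyl)phenyl in place of 3-(hydroxycarbamoyl)phenyl, and its floor lies within the scatter. Compound 3, `O=C(NO)c1cccc(-c2cn([C@H]3C[C@H](C(=O)O)N(CCCc4ccccc4)C3)nn2)c1`, differs from compound 1 on the saturated ring: carboxy in place of hydroxymethyl on a saturated ring carbon. Among the measured compounds shown here, no measured pair alters the hydroxymethyl group, so none of the measured steps bears on this change. Compound 3 is therefore expected to sit close to compound 1, with an expected step that the limit leaves unreadable from compound 1 to compound 3, not beyond the scatter. For compound 3 the estimated value in this assay is 8%, expected to lie between 0% and 25%.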

Compound 3, a percentage reported as inhibition, at one concentration (the size of the read-out at that concentration, not a potency): < 10%
Compound 3 was reported as a limit; the forecaster's own chance of this, stated with the estimate: 55%; the middle value lies beyond the limit too.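

Among these compounds, no step from compound 1 to compound 3 can be read, since the results for both compounds are limits of the assay and not numbers: the limit of < 10% in this assay, at which 2 of the 3 values shown sit. The compounds shown leave open whether carboxy in place of hydroxymethyl on a saturated ring carbon changes the inhibition in this assay at all.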